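Piperidin-1-yl for piperazin-1-yl on a saturated chain

The compounds below may be only part of what the source reports. "The series", "measured", "known", "first", "only" and "open" are said of these compounds alone.

In a functional assay on A-375 cells (Homo sapiens) for cytotoxicity, read by MTT assay, with a stated time of 72 h (a lower number here means a stronger inhibitor, a higher number a weaker inhibitor), compound 3 `O=C1c2c[n+]([O-])c3ccccc3c2C(=O)c2c1c1ccccc1n2CCCCN1CCNCC1` gives 460 nM, compound 2 `O=C1c2c[n+]([O-])c3ccccc3c2C(=O)c2c1c1ccccc1n2CCN1CCCC1` gives 430 nM and compound 1 `O=C1c2c[n+]([O-])c3ccccc3c2C(=O)c2c1c1ccccc1n2Cc1cn(C[C@H](O)CO)nn1` gives 350 nM. Compound 3 therefore cannot be told apart from the other two: a 1.3-fold higher number from compound 1 to compound 3 (0.12 log units; within the scatter) and a 1.1-fold higher number from compound 2 to compound 3 (0.03 log units; within the scatter). The remaining step, a 1.2-fold higher number from compound 1 to compound 2 (0.09 log units; within the scatter), is just as small. Compound 4 `O=C1c2c[n+]([O-])c3ccccc3c2C(=O)c2c1c1ccccc1n2CCCCN1CCCCC1` keeps the shared core and chain of compound 3 and alters only the end group: piperidin-1-yl in place of piperazin-1-yl on a saturated chain carbon, four bonds along the chain from an aromatic nitrogen. Going by the values given here, no measured step makes this exact swap. The nearest evidence is a 1.1-fold higher number from compound 2 to compound 3 (0.03 log units; within the scatter), which also changes the end group, so no shift beyond the scatter is expected. The expected step is a 1.2-fold lower number from compound 3 to compound 4 (0.06 log units; within the scatter). For compound 4 the estimated value is 400 nM, within a range of 200 nM to 800 nM.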

Compound 4, half-maximal inhibitory concentration: 190 nM
Estimate against measurement, compound 4: 2.1-fold (0.32 log units) above; measured number outside the range, below it.
By their numbers in this assay, from the lowest: compounds 4, 1, 2 and 3 (each within the scatter of the next, the first and the last beyond it).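

In this assay, going by these compounds alone, the step of a 2.4-fold lower number from compound 3 to compound 4 (0.38 log units; beyond the scatter) that puts piperidin-1-yl in place of piperazin-1-yl is the first here beyond the scatter, so the end group on this chain can shift the number. The step of a 2.3-fold lower number from compound 2 to compound 4 (0.35 log units; beyond the scatter) also lies beyond the scatter, but a 1.8-fold lower number from compound 1 to compound 4 (0.27 log units; within the scatter) stays within it, so compound 4 does not stand clear of every other compound. Nothing available explains the difference between these end groups.

As far as these compounds go, whether a morpholin-4-yl end group would behave like piperidin-1-yl or like piperazin-1-yl remains open. So does the effect of a longer chain carrying piperidin-1-yl.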